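The source may report more compounds than this note shows. Statements on the series, on what has been measured and on what is new or still open speak of the compounds shown alone.

Measured in an ADME assay on the whole organism (plasma, Macaca fascicularis) for protein binding, read by LC-MS, using equilibrium dialysis and cassette dosing, with a stated time of 24 h, at a dose of 1 mg/kg by the oral route; on this read-out lower numbers stand for a smaller free fraction and higher numbers for a larger free fraction:
- compound 1 `CCCCN(c1nc2c(C(=O)NC)cccc2o1)[C@H](C)c1ccc(-c2ccccc2-c2nnn[nH]2)cc1`: 0.000975
- compound 2 `CCCCN(c1nc2c(C(=O)O)cccc2o1)[C@H](C)c1ccc(-c2cc(Cl)ccc2-c2nc(=O)o[nH]2)cc1`: 0.000135
- compound 3 `CCCCN(c1nc2c(C(=O)O)cccc2o1)[C@H](C)c1ccc(-c2cc(F)ccc2-c2nc(=O)o[nH]2)cc1`: 0.0000736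

Compound 1 gives the highest unbound fraction of the three; compound 2 sits well below it and compound 3 lower still, both gaps beyond the scatter. For the measured compounds named here, the one measured single-point step, a 1.8-fold lower number from compound 2 to compound 3 (0.26 log units; within the scatter), concerns a halogen swap and lies within the scatter.

Compound 4 `CCCCN(c1nc2ccccc2o1)[C@H](C)c1ccc(-c2ccccc2-c2nnn[nH]2)cc1` differs from compound 1 by hydrogen in place of methylcarbamoyl on an aromatic carbon. Going by the values given here, no measured step touches this change; the chloro-to-fluoro step does not bear on it. With nothing comparable in hand, the expectation rests on compound 1 alone, and a modest step is expected, a 1.6-fold lower number from compound 1 to compound 4 (0.21 log units; within the scatter), possibly within the scatter. Compound 4 is estimated at 0.0006, range 0.0002 to 0.0015.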

Compound 4, unbound fraction: 0.000713
Beside the measured number, compound 4's estimate is 1.2-fold (0.07 log units) below it; measured number inside the range.
By their numbers in this assay, from the lowest: compounds 3 and 2 (each within the scatter of the next); then compounds 4 and 1 (each within the scatter of the next).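

Hydrogen in place of methylcarbamoyl on this aromatic carbon, ortho to a fused ring, gives a 1.4-fold lower number from compound 1 to compound 4 (0.14 log units; within the scatter) in this assay, the first reading at this position. In this pair, the unbound fraction shows no change beyond the scatter when the methylcarbamoyl group leaves. No measurement on hand explains the size of this step.

Open, from the compounds shown here alone, is what an amine or a methoxy group on this aromatic carbon would give, and whether the same replacement gives a step of similar size elsewhere.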